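Pyridin-2-yl for phenyl at the amine in two settings

A few compounds are considered here, and "the series" means these few. Any claim that something is new, unique, unknown or untested is made for them only; others in the source may bear on it.

Measured compounds:
compound 1, `COC(=O)C(C)(C)c1nc2n(Cc3ccccc3F)c(C)c(-c3cccc(OC)c3)c(=O)n2c1CN(C)Cc1ccccn1`: 4.2 nM
compound 2, `COC(=O)C(C)(C)c1nc2n(Cc3ccccc3F)c(C)c(-c3cccc(OC)c3)c(=O)n2c1CN(C)Cc1ccccc1`: 59 nM
compound 3, `COc1cccc(-c2c(C)n(Cc3ccccc3F)c3nc(C(C)(C)C)c(CNCc4ccccc4)n3c2=O)c1`: 240 nM

Of the compounds shown here, three have been tested in an assay on isolated protein for binding affinity to Gonadotropin-releasing hormone receptor (Homo sapiens) (a higher number here means a weaker inhibitor, a lower number a stronger inhibitor), and a fourth, compound 4 `COc1cccc(-c2c(C)n(Cc3ccccc3F)c3nc(C(C)(C)C)c(CNCc4ccccn4)n3c2=O)c1`, has not. Compound 3 gives the highest number of the three, 240 nM in this assay; compound 2 gives 59 nM and compound 1 gives 4.2 nM. The difference between the cores of compound 3 and compound 2 is not broken down here.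

One change is shown twice. From compound 2 to compound 1 it is pyridin-2-yl in place of phenyl on a saturated chain carbon bound to an amine nitrogen, and it brought a 14-fold lower number from compound 2 to compound 1 (1.15 log units; beyond the scatter). From compound 3 to compound 4 it is pyridin-2-yl in place of phenyl on a saturated chain carbon bound to an amine nitrogen. Cut one bond further out, the first change turns a benzyl(methyl)amino into a methyl((pyridin-2-yl)methyl)amino, the second a benzylamino into a ((pyridin-2-yl)methyl)amino, so the surroundings are not identical.

Compound 4 is therefore expected to lie well below compound 3, with an estimated step of a 9.6-fold lower number from compound 3 to compound 4 (0.98 log units; beyond the scatter), because the same change gave a 14-fold lower number from compound 2 to compound 1 (1.15 log units; beyond the scatter). For the measured compounds named here, with only one prior instance, and that in a different amine setting, the estimate is kept somewhat more cautious than a direct repeat would suggest. Compound 4 is estimated at 25 nM in this assay, most likely between 8 nM and 80 nM.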

Compound 4, inhibition constant: 30 nM
Beside the measured number, compound 4's estimate is 1.2-fold (0.08 log units) below it, within the range that was stated.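

In this assay, the swap of phenyl for pyridin-2-yl on the saturated chain carbon bound to an amine nitrogen gave an 8.0-fold lower number from compound 3 to compound 4 (0.90 log units; beyond the scatter), so the direction seen on the first core held on the second, where the amine carries no methyl group. The size of the gain also carried over, with no difference between the two steps that stands out from the scatter: the same change on two cores in this assay, a 14-fold lower number (1.15 log units; beyond the scatter) from compound 2 to compound 1 and an 8.0-fold lower number (0.90 log units; beyond the scatter) from compound 3 to compound 4, 1.8-fold (0.24 log units) apart, within the scatter of two such steps. This shows that the change transferred between these two cores, one of which pairs the methylated amine with its own core and the other the unmethylated amine with a tert-butyl core, but two pairs do not establish a rule for the series, and they say nothing about why the gain arises.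

The two pairs differ in both the amine and the rest of the core, so the separate contributions of the methyl group on the amine and of the tert-butyl group remain unresolved. Also open, as far as these compounds go, is whether the gain depends on where the ring nitrogen sits, as pyridin-3-yl or pyridin-4-yl would test, and whether it would survive a longer chain between the ring and the amine or on a core bearing a carboxylic acid.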